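Hydrazinylpyridine in place of aminopyrimidine on the shared core

The source may report more compounds than this note shows. Statements on the series, on what has been measured and on what is new or still open speak of the compounds shown alone.

Measured so far:
compound 3 `Nc1nccc(-c2c(-c3ccc(F)cc3)nn3c(NC4CCCC4)cccc23)n1` — 46000 nM
compound 1 `Fc1ccc(-c2nn3c(NC4CCCC4)cccc3c2-c2ccc(NC3CCCC3)nc2)cc1` — "not determined" (no result reported)
compound 2 `Fc1ccc(-c2nn3c(NC4CCCC4)cccc3c2-c2ccnc(F)c2)cc1` — "not determined" (no result reported)

Three compounds on one core have been run in an ADME assay on Vero cells (Chlorocebus sabaeus) for cytotoxicity (a lower number here means that less compound is tolerated, a higher number that more compound is tolerated), but only compound 3 returns a number. For compound 1 the entry in this assay reads "not determined" (no result reported), and for compound 2 it likewise reads "not determined" (no result reported). For the measured compounds named here, compound 3 therefore stands alone; no comparison between measured compounds is available, and nothing can be said about how the series as a whole behaves in this assay.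

Compound 4 `NNc1cc(-c2c(-c3ccc(F)cc3)nn3c(NC4CCCC4)cccc23)ccn1` differs from compound 3 in one place: 2-(aminoamino)pyridin-4-yl in place of 2-aminopyrimidin-4-yl on an aromatic carbon. The rest of the molecule, including the 4-fluorophenyl group and the cyclopentylamino substituent, is unchanged.

Going by the values given here, with no measured step, the expectation rests on the size of the change alone. A shift from compound 3 to compound 4 of a 1.2-fold lower number from compound 3 to compound 4 (0.06 log units; within the scatter) is expected, which is no more than the usual scatter. Compound 4 is therefore estimated at 40000 nM, with a range from 15000 nM to 100000 nM.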

Compound 4, half-maximal cytotoxic concentration: 40000 nM
Estimate against measurement, compound 4: no gap at the digits printed, and the stated range covers the measured number.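

In this assay, placing 2-(aminoamino)pyridin-4-yl in place of 2-aminopyrimidin-4-yl on this aromatic carbon gives a 1.2-fold lower number from compound 3 to compound 4 (0.06 log units; within the scatter), a step within the scatter. For the compounds shown here, this is the first readable step, and it shows that this particular exchange at this position leaves the read-out indistinguishable between the two compounds. Nothing available explains this result.

On these data alone, whether the read-out stays as unresponsive at this position with a different kind of group, such as a carboxylic acid or an unsubstituted phenyl ring, remains open. Going by these compounds alone, the single step also says nothing about the 4-fluorophenyl group or the cyclopentylamino substituent, since both are unchanged between compound 3 and compound 4.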